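Piperazinyl Amide in Place of a Methanesulfonamido Chain

This account rests on a few compounds, and the source may have more. Where it says the series, first, only, none or still open, it means among the compounds named here.

Measured compounds:
compound 1, `CC(C)(C)OC(=O)NCCCCNC(=O)CN1CN(c2ccccc2)C2(CCN(C(=O)c3ccc(C(C)(C)C)cc3)CC2)C1=O`, in an assay on HEK293 cells for displacement of a labelled ligand from NPC1-like intracellular cholesterol transporter 1 (Homo sapiens) (a lower number here means a stronger inhibitor, a higher number a weaker inhibitor), gives "not determined" (no result reported);
compound 2, `CC(C)(C)c1ccc(C(=O)N2CCC3(CC2)C(=O)N(CC(=O)NCNS(C)(=O)=O)CN3c2ccccc2)cc1`, in this assay gives 3200 nM.

Among the compounds with values here, compound 2 therefore holds the only number in this assay, with compound 1 standing beside it without a result. Compound 3, `CC(C)(C)c1ccc(C(=O)N2CCC3(CC2)C(=O)N(CC(=O)N2CCNCC2)CN3c2ccccc2)cc1`, differs from compound 2 in one place: piperazin-1-yl in place of ((methanesulfonamido)methyl)amino on a carbonyl carbon. Within the data shown here, no step between measured compounds is available to calibrate such a change, so the expectation rests on compound 2 alone. Compound 3 is expected to move by a 1.1-fold lower number from compound 2 to compound 3 (0.03 log units; within the scatter), a step within the usual scatter in either direction. For compound 3 the estimate is 3000 nM, with a range from 800 nM to 12000 nM.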

Compound 3, half-maximal inhibitory concentration: 22000 nM
Compound 3: middle estimate off by 7.3-fold (0.87 log units), on the low side; measured number outside the range, above it.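

In this assay, piperazin-1-yl in place of ((methanesulfonamido)methyl)amino on a carbonyl carbon gives a 6.9-fold higher number from compound 2 to compound 3 (0.84 log units; beyond the scatter), a step beyond the scatter. This first step at the position shows that the number responds to what sits on this carbonyl carbon, and that here the open chain gives the stronger inhibitor of the pair. Nothing measured here accounts for the step.

Going by these compounds, it remains open whether the ring or the loss of the methanesulfonamido group carries the step. A methanesulfonyl group on the free piperazine nitrogen, or an open-chain amine such as dimethylamino on the same carbonyl carbon, would separate the two.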